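The compounds below may be only part of what the source reports. "The series", "measured", "known", "first", "only" and "open" are said of these compounds alone.

For the measured compounds named here, compound 2 `Cc1cc(N)c(S(C)(=O)=O)cc1C(=O)N=C(N)N` holds the lowest of the two numbers known so far: in a functional assay for inhibition of sodium/hydrogen exchanger (Oryctolagus cuniculus) (on this read-out lower numbers stand for stronger inhibition and higher numbers for weaker inhibition), compound 2 gives 16 nM, while compound 1 `Cc1cc(F)c(S(C)(=O)=O)cc1C(=O)N=C(N)N` gives 44 nM. Going by the values given here, the one measured step, a 2.8-fold lower number from compound 1 to compound 2 (0.44 log units; beyond the scatter), is modest yet beyond the scatter. Compound 3 `Cc1cc(C#N)c(S(C)(=O)=O)cc1C(=O)N=C(N)N` differs from compound 2 by cyano in place of amino on an aromatic carbon. Among the compounds with values here, no measured step involves a cyano group, so only the fluoro-to-amino step bears on the change, and it points to a modest rise in this assay once the amino is gone. Compound 3 is therefore expected near 40 nM, within 12 nM to 130 nM, an expected step of a 2.5-fold higher number from compound 2 to compound 3 (0.40 log units; beyond the scatter).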

Compound 3, half-maximal inhibitory concentration: 70 nM
The estimate for compound 3 lay 1.8-fold (0.24 log units) below the measured number; the range from low to high includes it.
By their numbers in this assay, from the lowest: compound 2; then compounds 1 and 3 (each within the scatter of the next).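

At this position, ortho to a methylsulfonyl group, cyano in place of amino gives a 4.4-fold higher number from compound 2 to compound 3 (0.64 log units; beyond the scatter) in this assay and so takes the number back out of the low range held by compound 2. Cyano in place of fluoro gives a 1.6-fold higher number from compound 1 to compound 3 (0.20 log units; within the scatter) and leaves those two groups unresolved, so among the three groups only amino stands apart beyond the scatter. Whether a hydroxyl group or a methylamino group would match amino here remains open, and no measurement shown accounts for the difference.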